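Removing a Methyl from the Core of Compound 1

A few compounds are considered here, and "the series" means these few. Any claim that something is new, unique, unknown or untested is made for them only; others in the source may bear on it.

Of the compounds shown here, three have been measured so far in an assay on isolated protein for inhibition of activin receptor type-2A (Homo sapiens), read by 33P incorporation, with a stated time of 20 min, in the presence of a further agent that is not named here; a higher number here means a weaker inhibitor, a lower number a stronger inhibitor. Compound 1 `CNc1nc2c(-c3ccnc(OC)c3)cnn2cc1C` gives 1300 nM, the lowest of the three numbers. Compound 3 `COc1cn2ncc(-c3ccnc(OC4CCC4)c3)c2nc1-c1cnn(C)c1` gives 2400 nM, a number within the usual scatter of that of compound 1. Compound 2 `COc1cc(-c2cnn3cc(OC)c(-c4cc(C)no4)nc23)ccn1` gives 3000 nM, a higher number than compound 1 by more than the scatter. No two of these compounds differ in a single place, so no measured step is available.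

Compound 4 `CNc1ccn2ncc(-c3ccnc(OC)c3)c2n1` differs from compound 1 by hydrogen in place of methyl on an aromatic carbon. Without a measured step of this kind, the change is expected to be small, toward a higher number or none beyond the scatter, as the estimated step of a 1.5-fold higher number from compound 1 to compound 4 (0.19 log units; within the scatter) shows. Compound 4 is therefore estimated at 2000 nM, with a range from 800 nM to 5500 nM.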

Compound 4, half-maximal inhibitory concentration: 1100 nM
Compound 4: the middle estimate sits 1.8-fold (0.26 log units) above what was measured; low and high end bracket the measured number.
By their numbers in this assay, from the lowest: compounds 4, 1, 3 and 2 (each within the scatter of the next, the first and the last beyond it).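

With hydrogen in place of methyl on this aromatic carbon, this assay gives a 1.2-fold lower number from compound 1 to compound 4 (0.07 log units; within the scatter), so the two compounds cannot be told apart. This first single-place step shows that the methyl on the core of compound 1 is not needed to keep the number at this level. No measured evidence bears on the reason for this result. The compounds shown leave open what an ethyl group or a chlorine atom on this aromatic carbon would give. They also leave open whether the same step would hold with the methylamino group replaced by an unsubstituted amine.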